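Thiosemicarbazone series: anilino substituent swap on the shared core

The source may hold more compounds than are shown below. What is called first, only, known or untested is meant among the compounds shown, and "the series" means these compounds.

Measured compounds:
- compound 1 `Fc1cccc(NC(=S)N/N=C/c2ccc3ccccc3n2)c1`, 70100 nM in a functional assay on HeLa cells (Homo sapiens) for antiproliferative activity, read by sulforhodamine B assay, with a stated time of 72 h; on this read-out lower numbers stand for stronger inhibition and higher numbers for weaker inhibition
- compound 2 `Cc1ccc(NC(=O)N/N=C/c2ccc3ccccc3n2)cc1`, > 100000 nM in this assay
- compound 3 `NC(=S)N/N=C/c1nc2ccccc2s1`, 5350 nM in this assay

Of the two numbers in hand, compound 1 gives the higher one. Compound 3, which carries a different core and no aryl group on the thiourea nitrogen, gives a clearly lower number, and the gap between compound 3 and compound 1 lies beyond the usual scatter. For compound 2 this assay reports only a limit, (the limit of > 100000 nM in this assay, at which 1 of the 3 values shown sits), so no number stands against it.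

Compound 4 `Cc1ccc(NC(=S)N/N=C/c2ccc3ccccc3n2)cc1` has not yet been measured in this assay. Relative to compound 1 it differs in one place: 4-methylphenyl in place of 3-fluorophenyl on an amide-type nitrogen. Among the compounds with values here, the aryl group on the thiourea nitrogen is thus exchanged for the one carried by compound 2, while the thiocarbonyl of compound 1 is kept. Within the data shown here, no measured pair in hand isolates this exchange, so the size of the step is not known from the data.

The step from compound 1 to compound 4 is expected to be small, a 1.1-fold higher number from compound 1 to compound 4 (0.06 log units; within the scatter), most likely none beyond the scatter. Compound 4 is estimated at 80000 nM in this assay, within a range of 25000 nM to 250000 nM.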

Compound 4, half-maximal inhibitory concentration: 86000 nM
The estimate for compound 4 lay 1.1-fold (0.03 log units) below the measured number; low and high end bracket the measured number.
By their numbers in this assay, from the lowest: compound 3; then compounds 1 and 4 (each within the scatter of the next). At a limit, above all of these: compound 2.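

In this assay, within the data shown here, the thiourea nitrogen of the shared core was varied for the first time with the thiocarbonyl held constant, and exchanging 3-fluorophenyl for 4-methylphenyl gives a 1.2-fold higher number from compound 1 to compound 4 (0.09 log units; within the scatter). This single pair therefore does not separate the two aryl groups at this position, and neither group can be ranked above the other on this read-out. Compound 4 also forms a one-place pair with compound 2, which carries a carbonyl in place of the thiocarbonyl, but that step cannot be read because compound 2 gives only a limit: the limit of > 100000 nM in this assay, at which 1 of the 4 values shown sits.

Still open, going by these compounds, is whether a dimethylamino group or a carboxylic acid on the phenyl ring, or a longer alkyl chain in place of the aryl group, would shift the number on the shared core beyond the scatter. Also open, on these data alone, is how the number of compound 3 relates to this pair, since compound 3 differs from compound 1 and compound 4 in more than one place and cannot be compared with them directly.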